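The compounds below may be only part of what the source reports. "The series", "measured", "known", "first", "only" and "open" are said of these compounds alone.

Values in a functional assay on MCF7 cells (Homo sapiens) for inhibition, read by MTT assay, with a stated time of 72 h; on this read-out higher numbers stand for weaker inhibition and lower numbers for stronger inhibition:
- compound 1 `COc1ccc(-c2nnc(SCCCN3CCN(c4nc5ccccc5o4)CC3)o2)cc1`: 52800 nM
- compound 2 `O=[N+]([O-])c1ccc(-c2nnc(SCCCN3CCN(c4nc5ccccc5o4)CC3)o2)cc1`: 90100 nM
- compound 3 `COc1ccc(-c2nnc(SCCCN3CCN(c4nc5ccccc5s4)CC3)o2)cc1`: 171000 nM

Compound 3 stands within the usual scatter of compound 2, whose value is 90100 nM. Its number is higher than that of compound 1, with a 3.2-fold higher number from compound 1 to compound 3 (0.51 log units; beyond the scatter). That step, 1,3-benzothiazol-2-yl in place of 1,3-benzoxazol-2-yl on an amine nitrogen in a ring, gives the background that compound 3 and compound 4 share.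

Compound 4 `O=[N+]([O-])c1ccc(-c2nnc(SCCCN3CCN(c4nc5ccccc5s4)CC3)o2)cc1` differs from compound 3 by nitro in place of methoxy on an aromatic carbon: 4-methoxyphenyl becomes 4-nitrophenyl. Going by the values given here, only one measured step carries this same change, a 1.7-fold higher number from compound 1 to compound 2 (0.23 log units; within the scatter), and it stayed within the scatter. As far as these compounds go, it was seen once, on the other background, so its transfer is untested. No step beyond the scatter is expected in this assay, with at most a slight drift towards a higher number.

Compound 4 is expected at 230000 nM, with an estimated range of 100000 nM to 450000 nM. The estimate means a 1.3-fold higher number from compound 3 to compound 4 (0.13 log units; within the scatter), which is expected to stay within the scatter.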

Compound 4, half-maximal inhibitory concentration: 118000 nM
For compound 4 the middle estimate is 1.9-fold (0.29 log units) above the measured one, within the range that was stated.
By their numbers in this assay, from the lowest: compounds 1, 2, 4 and 3 (each within the scatter of the next, the first and the last beyond it).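

In this assay, replacing 4-methoxyphenyl with 4-nitrophenyl gives a 1.4-fold lower number from compound 3 to compound 4 (0.16 log units; within the scatter) on the second core, so this position now shows no step beyond the scatter on either core: the same change on two cores in this assay, a 1.7-fold higher number (0.23 log units; within the scatter) from compound 1 to compound 2 and a 1.4-fold lower number (0.16 log units; within the scatter) from compound 3 to compound 4, 2.5-fold (0.39 log units) apart, within the scatter of two such steps. With 4-nitrophenyl in place, 1,3-benzothiazol-2-yl in place of 1,3-benzoxazol-2-yl gives a 1.3-fold higher number from compound 2 to compound 4 (0.12 log units; within the scatter) and so does not repeat as a step beyond the scatter, although the gap to the 4-methoxyphenyl pair stays within the scatter of two such steps: the same change on two cores in this assay, a 3.2-fold higher number (0.51 log units; beyond the scatter) from compound 1 to compound 3 and a 1.3-fold higher number (0.12 log units; within the scatter) from compound 2 to compound 4, 2.5-fold (0.39 log units) apart, within the scatter of two such steps. The step from compound 1 to compound 3 therefore remains a single reading beyond the scatter, without support on the 4-nitrophenyl background.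

As far as these compounds go, whether an amine or a carboxylic acid in place of methoxy and nitro on this aromatic carbon would give a step beyond the scatter remains open. Also open, from the compounds shown here alone, is whether a longer chain in the linker would do so.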